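The source may hold more compounds than are shown below. What is called first, only, known or untested is meant among the compounds shown, and "the series" means these compounds.

Measured compounds in an ADME assay on Vero cells (Chlorocebus sabaeus) for cytotoxicity, read by MTT assay, with a stated time of 72 h; on this read-out lower numbers stand for higher toxicity in this test and higher numbers for lower toxicity in this test:
Compound 1 `CC(C)(C)C(=O)N1CCN(c2nc(=O)c3cc(C(F)(F)F)cc([N+](=O)[O-])c3s2)CC1` gives > 125000 nM, a limit of the assay.
Compound 2 `O=C(C1CC1)N1CCN(c2nc(=O)c3cc(C(F)(F)F)cc([N+](=O)[O-])c3s2)CC1` gives > 125000 nM, a limit of the assay.
Compound 3 `O=C(C1CCCCC1)N1CCN(c2nc(=O)c3cc(C(F)(F)F)cc([N+](=O)[O-])c3s2)CC1` gives 88700 nM.

Compound 3 is the only one of the three for which this assay returns a number; the other two values sit at a limit (the limit of > 125000 nM in this assay, at which 2 of the 3 values shown sit). Compound 4 `CCC(=O)N1CCN(c2nc(=O)c3cc(C(F)(F)F)cc([N+](=O)[O-])c3s2)CC1` has not yet been measured. It differs from compound 3 by ethyl in place of cyclohexyl on a carbonyl carbon. Going by the values given here, two measured steps bear on this change, both arriving at compound 3 from a smaller group on the same carbonyl carbon: an at least 1.4-fold lower number from compound 1 to compound 3 (0.14 log units; that floor lies within the scatter) and an at least 1.4-fold lower number from compound 2 to compound 3 (0.14 log units; that floor lies within the scatter). The step between the two smaller groups, a step that the two limits leave unreadable from compound 1 to compound 2, adds nothing readable. What these steps show is that the cyclohexyl compound alone gives a number, while tert-butyl and cyclopropyl are reported as limits; ethyl, like those two, brings no six-membered ring. Compound 4 is therefore expected to move back toward the limit region, a step of a 1.7-fold higher number from compound 3 to compound 4 (0.23 log units; within the scatter) in this assay, with a good chance that only a limit is reported. The estimate for compound 4 is 150000 nM, with a range from 80000 nM to 300000 nM.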

Compound 4, half-maximal cytotoxic concentration: > 125000 nM
Compound 4 ended at the assay's limit; the forecaster's own chance of this, stated with the estimate: 70%; the middle value lies beyond the limit too.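

In this assay, ethyl in place of cyclohexyl on the carbonyl carbon gives an at least 1.4-fold higher number from compound 3 to compound 4 (0.14 log units; that floor lies within the scatter), and as printed that floor lies within the scatter, so it establishes no real gap between these two groups. What is new at this position is that an open chain with no ring now joins tert-butyl and cyclopropyl at the limit, which leaves the cyclohexyl group of compound 3 as the only one of the four that returns a number. The steps from compound 1 and from compound 2 to compound 4 cannot be read, as both ends of each are limits and not numbers: the limit of > 125000 nM in this assay, at which 3 of the 4 values shown sit.

The compounds shown leave open whether a longer chain such as hexanoyl, with as many carbons as the cyclohexyl group or more, would return a number as compound 3 does, or whether a phenyl or cyclopentyl group on the same carbonyl carbon would. They also leave open how an amine or a carboxylic acid carried on that acyl group would read in this assay.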